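Bromophenoxy swap on the spiro core: compound 2 to compound 4

The source may hold more compounds than are shown below. What is called first, only, known or untested is meant among the compounds shown, and "the series" means these compounds.

Compound 2 `Cc1ccc(OCCCON2C(N)=NC(N)=NC23CCOCC3)cc1` is reported as "not determined" (no result reported) in a functional assay on MDA-MB-231 cells (Homo sapiens) for antiproliferative activity, read by MTT assay, with a stated time of 72 h; a lower number here means a stronger inhibitor, a higher number a weaker inhibitor; it stands without a number, so the step to compound 4 has no measured starting point. Compound 4 `NC1=NC2(CCOCC2)N(OCCCOc2cccc(Br)c2)C(N)=N1` shares the core of compound 2 and differs from it only at the aryl group: 3-bromophenyl in place of 4-methylphenyl on an oxygen on a saturated carbon. Nothing measured on that core anchors the change. Within the data shown here, the only bearing steps come from the other core: compound 1 `NC1=NC2(CCSCC2)N(OCCCOc2cccc(Cl)c2)C(N)=N1` gives 130 nM in this assay, and compound 3 `NC1=NC2(CCSCC2)N(OCCCOc2ccc(Br)cc2)C(N)=N1` gives 440 nM. The one-place step a 3.4-fold higher number from compound 1 to compound 3 (0.53 log units; beyond the scatter) shows that moving from a 3-chlorophenyl to a 4-bromophenyl raised the number modestly. Compound 4 carries a 3-bromophenyl, halogen placed as in compound 1 but bromine as in compound 3, so a value between those two seems the reasonable expectation, widened for the change of core. Compound 4 is therefore estimated at 250 nM, with a likely range from 80 nM to 800 nM.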

Compound 4, half-maximal inhibitory concentration: 400 nM
Compound 4: the middle estimate sits 1.6-fold (0.20 log units) below what was measured; low and high end bracket the measured number.
By their numbers in this assay, from the lowest: compound 1; then compounds 4 and 3 (each within the scatter of the next).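

In this assay compound 2 has no number, so the step to compound 4 cannot be read. No supporting evidence bears on this result. The compounds shown leave open how the 3-bromophenyl group and the core of compound 4 each contribute to its value.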